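Aryl substituent variation on the benzylamine of the shared core

The source may report more compounds than this note shows. Statements on the series, on what has been measured and on what is new or still open speak of the compounds shown alone.

Three compounds share one core and differ only in the aryl group on the saturated chain carbon bound to the ring nitrogen. In a functional assay on DU-145 cells (Homo sapiens) for inhibition, read by sulforhodamine B assay, with a stated time of 48 h (a higher number here means a weaker inhibitor of growth, a lower number a stronger inhibitor of growth), compound 1 `Nc1cc(N)c2nc(-c3ccccc3)c(NCc3ccc(Cl)c(Cl)c3)nc2c1` gives 16200 nM. Compound 2 `COc1ccc(CNc2nc3cc(N)cc(N)c3nc2-c2ccccc2)cc1OC` gives 460 nM in this assay. Compound 3 `Nc1cc(N)c2nc(-c3ccccc3)c(NCc3ccc(F)cc3)nc2c1` gives 1510 nM in this assay, which places it second of the three numbers: a 3.3-fold higher number from compound 2 to compound 3 (0.52 log units; beyond the scatter), while an 11-fold lower number from compound 1 to compound 3 (1.03 log units; beyond the scatter). Compound 4 `COc1ccc(CNc2nc3cc(N)cc(N)c3nc2-c2ccccc2)cc1` has not yet been measured. The change from compound 3 to compound 4 is methoxy in place of fluoro on an aromatic carbon, sitting on an aromatic carbon of a six-membered aromatic ring of carbon only, para to a large group; cut one bond further out it reads 4-fluorophenyl to 4-methoxyphenyl. Going by the values given here, the step that bears most directly on it is the one between compound 2 and compound 3, where a 3.3-fold higher number from compound 2 to compound 3 (0.52 log units; beyond the scatter); the large step of a 35-fold lower number from compound 1 to compound 2 (1.55 log units; beyond the scatter) points the same way for methoxy-bearing aryl groups. Compound 4 carries one methoxy group where compound 2 carries two, so in this assay a modest move toward the number of compound 2 is expected, written as a 2.0-fold lower number from compound 3 to compound 4 (0.30 log units; within the scatter). For compound 4 the expected value in this assay is 750 nM, with a range from 350 nM to 1600 nM.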

Compound 4, concentration for 50% growth inhibition: 21900 nM
Compound 4: middle estimate off by 29-fold (1.47 log units), on the low side, outside the stated range (above it).
By their numbers in this assay, from the lowest: compound 2; then compound 3; then compounds 1 and 4 (each within the scatter of the next).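

Adding only one methoxy group does not give a partial version of the compound 2 result in this assay: with hydrogen in place of methoxy on an aromatic carbon there is a 48-fold higher number from compound 2 to compound 4 (1.68 log units; beyond the scatter) and most of the advantage of the 3,4-dimethoxyphenyl group is lost. Going by these compounds alone, the swap of fluoro for methoxy at this place, on an aromatic carbon para to a large group, is also no minor exchange: it gives a 15-fold higher number from compound 3 to compound 4 (1.16 log units; beyond the scatter) and leaves 4-fluorophenyl clearly ahead of 4-methoxyphenyl, an order that the earlier compounds could not show. With a 1.4-fold higher number from compound 1 to compound 4 (0.13 log units; within the scatter) the 4-methoxyphenyl and 3,4-dichlorophenyl groups are not told apart, so the link between methoxy-bearing aryl groups and low numbers rests on compound 2 alone, and compound 4 goes against it.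

Still open, going by these compounds, is whether the low number of compound 2 needs both methoxy groups together, and whether a hydroxy group or an amine at the same place, or a longer chain in place of the single chain carbon, would follow compound 2 or compound 4. No measurement at hand gives a reason for these steps.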